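From methylsulfonyl to (2-hydroxyethyl)amino in compound 3

The compounds below may be only part of what the source reports. "The series", "measured", "known", "first", "only" and "open" are said of these compounds alone.

In a functional assay on MCF7 cells (Homo sapiens) for cytotoxicity, read by fluorescence, with a stated time of 72 h (a higher number here means a weaker inhibitor, a lower number a stronger inhibitor), compound 1 `CSc1nc(NCc2ccc(-c3ccccn3)cc2)c2[nH]nc(C(C)C)c2n1` gives 819 nM and compound 2 `CC(C)c1n[nH]c2c(NCc3ccc(-c4ccccn4)cc3)nc(S(C)(=O)=O)nc12` gives 460 nM. Within the data shown here, these two values lie within the scatter of each other, so compound 2 stands level with its only measured neighbour. Compound 3 `CC(C)c1n[nH]c2c(NCc3ccc(-c4ccccn4)cc3)nc(NCCO)nc12` carries (2-hydroxyethyl)amino in place of methylsulfonyl on an aromatic carbon. Among the measured compounds shown here, one measured step bears on this place, methylsulfonyl in place of methylsulfanyl, which gives a 1.8-fold lower number from compound 1 to compound 2 (0.25 log units; within the scatter). For the measured compounds named here, that single step stays inside the scatter, and no measured compound yet carries the entering group, so the guidance is weak. No step beyond the scatter is therefore expected in this assay, and no firm direction is expected either. The estimated step is a 1.2-fold lower number from compound 2 to compound 3 (0.06 log units; within the scatter). For compound 3 the estimate is 400 nM, with an expected range of 130 nM to 1200 nM.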

Compound 3, half-maximal inhibitory concentration: 51 nM
For compound 3 the middle estimate is 7.8-fold (0.89 log units) above the measured one, and the stated range ends above it.
By their numbers in this assay, from the lowest: compound 3; then compounds 2 and 1 (each within the scatter of the next).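

In this assay this position, on an aromatic carbon between two ring nitrogen atoms, proves responsive: (2-hydroxyethyl)amino gives a 9.0-fold lower number from compound 2 to compound 3 (0.96 log units; beyond the scatter) and, against the methylsulfanyl compound, a 16-fold lower number from compound 1 to compound 3 (1.21 log units; beyond the scatter), whereas the exchange between the two sulfur groups stayed within the scatter. Methylsulfonyl and (2-hydroxyethyl)amino match in heavy-atom count and hydrogen-bond acceptors and differ in hydrogen-bond donors, so a change at this place can shift the number well beyond the scatter with no change in the heavy-atom count. Nothing at hand accounts for the size of this step.

The compounds shown leave open whether the hydroxyl or the ring-bound amine nitrogen carries the step. A plain ethylamino group, a methoxyethylamino group or a longer chain such as (3-hydroxypropyl)amino would separate these readings.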